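The source may report more compounds than this note shows. Statements on the series, on what has been measured and on what is new or still open speak of the compounds shown alone.

Measured so far in an ADME assay on microsomes (Mus musculus) for metabolic stability; on this read-out lower numbers stand for slow clearance and higher numbers for fast clearance
Compound 1 `CNC(=O)[C@@H]1CCCN1S(=O)(=O)c1ccc(Cl)c(COc2cccc3c(C(F)(F)F)cc(C)nc23)c1Cl` gives 1380 mL/min/kg
Compound 2 `Cc1cc(C(F)(F)F)c2cccc(OCc3c(Cl)ccc(S(=O)(=O)N4CCC[C@H]4C(N)=O)c3Cl)c2n1` gives 12600 mL/min/kg
Compound 3 `COC[C@@H]1CCCN1S(=O)(=O)c1ccc(Cl)c(COc2cccc3c(C(F)(F)F)cc(C)nc23)c1Cl` gives 1620 mL/min/kg

Compound 3 stands at 1620 mL/min/kg in this assay and lies within the scatter of compound 1 (a 1.2-fold higher number from compound 1 to compound 3 (0.07 log units; within the scatter)). The carbamoyl compound sits apart (a 7.8-fold lower number from compound 2 to compound 3 (0.89 log units; beyond the scatter)), and removing the methyl from the amide-type nitrogen alone accounts for a similar distance (a 9.1-fold higher number from compound 1 to compound 2 (0.96 log units; beyond the scatter)).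

Compound 4 `Cc1cc(C(F)(F)F)c2cccc(OCc3c(Cl)ccc(S(=O)(=O)N4CCCCC4)c3Cl)c2n1` differs from compound 3 at the sulfonamide (piperidin-1-yl in place of 2-(methoxymethyl)pyrrolidin-1-yl on a sulfonyl sulfur), with piperidin-1-yl in place of 2-(methoxymethyl)pyrrolidin-1-yl on a sulfonyl sulfur. Within the data shown here, none of the measured steps alters the ring on the sulfonyl sulfur. All three exchange only the group on its saturated ring carbon, so they bear on this change indirectly. Among the measured compounds shown here, compound 4 lacks the carbamoyl group of compound 2, the one compound that stands apart, so no step beyond the scatter is expected, though with wide uncertainty. The expected step is small (a 1.1-fold higher number from compound 3 to compound 4 (0.05 log units; within the scatter)). Compound 4 is expected at 1800 mL/min/kg in this assay, with an estimated range from 700 mL/min/kg to 5000 mL/min/kg for a measurement.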

Compound 4, clearance: 1000 mL/min/kg
Compound 4: the middle estimate sits 1.8-fold (0.26 log units) above what was measured; the range from low to high includes it.
By their numbers in this assay, from the lowest: compounds 4, 1 and 3 (each within the scatter of the next); then compound 2.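

In this assay, among these compounds, the ring on the sulfonyl sulfur now changes for the first time, and piperidin-1-yl stays within the scatter whether it replaces 2-(methoxymethyl)pyrrolidin-1-yl (a 1.6-fold lower number from compound 3 to compound 4 (0.21 log units; within the scatter)) or 2-(methylcarbamoyl)pyrrolidin-1-yl (a 1.4-fold lower number from compound 1 to compound 4 (0.14 log units; within the scatter)). Against 2-carbamoylpyrrolidin-1-yl the step is large and beyond the scatter (a 13-fold lower number from compound 2 to compound 4 (1.10 log units; beyond the scatter)), so among these four compounds a piperidin-1-yl with no group on a saturated ring carbon groups with compound 1 and compound 3, leaving compound 2 as the only one apart. Nothing measured here gives a cause for this split.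

The change to piperidin-1-yl alters the ring size, removes the group on the saturated ring carbon and removes the defined stereocentre all at once, so the four compounds cannot show what each of these contributes; an unsubstituted pyrrolidin-1-yl or a piperidin-1-yl carrying a carbamoyl group would begin to separate them. Going by these compounds, it also remains open how a morpholin-4-yl or a dimethylamino group on the sulfonyl sulfur would read on this scale.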